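Imidazole to benzimidazole on a triphenylpropyl chain

The source may report more compounds than this note shows. Statements on the series, on what has been measured and on what is new or still open speak of the compounds shown alone.

Measured compounds:
- compound 1, `c1ccc(-c2cccc(Cn3ccnc3)c2)cc1`: 38%
- compound 2, `c1ccc(C(CCn2ccnc2)(c2ccccc2)c2ccccc2)cc1`: 38%
- compound 3, `c1ccc(-c2ccccc2Cn2cnc3ccccc32)cc1`: "not active" (no number reported)

In an assay for inhibition of Aromatase (Homo sapiens), using microsomes, tested at 500 nM (on this read-out lower numbers stand for less inhibition and higher numbers for more inhibition at the one concentration tested (going by the name of the read-out)), compound 2 gives 38%. In this assay compound 1 gives 38%, so compound 2 stands level with compound 1 at the digits shown, with no difference beyond the usual scatter. Compound 3 carries the 1H-benzimidazol-1-yl group in a different setting, and in this assay compound 3 is reported as "not active" (no number reported), without a number.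

Compound 4, `c1ccc(C(CCn2cnc3ccccc32)(c2ccccc2)c2ccccc2)cc1`, differs from compound 2 in one place: 1H-benzimidazol-1-yl in place of 1H-imidazol-1-yl on a saturated chain carbon, three bonds along the chain from three aromatic carbons. Among the measured compounds shown here, no step between measured compounds shows what this exchange does on its own. The only hint in the set is compound 3, which carries the larger group and was reported as not active, yet it differs from the other compounds in more than one respect, so it cannot settle the question.

For compound 4 the expectation is a modest fall in this assay, with the step of a number 13 percentage points lower from compound 2 to compound 4 (beyond the scatter) expected to reach beyond the scatter but not to wipe out inhibition. Compound 4 is therefore estimated at 25%, within a range from 5% to 45%.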

Compound 4, a percentage reported as inhibition, at one concentration (the size of the read-out at that concentration, not a potency): "not active" (no number reported)
No number was reported for compound 4; there is nothing to compare the estimate with.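

Among the compounds shown here, compound 4 is reported as not active without a number, so no step from compound 2 to compound 4 can be read. Nothing shown here offers an explanation for this result. The compounds shown leave open how 1H-benzimidazol-1-yl in place of 1H-imidazol-1-yl changes inhibition on its own.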